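This account rests on a few compounds, and the source may have more. Where it says the series, first, only, none or still open, it means among the compounds named here.

Measured so far in an assay on HEK293 cells for inhibition of N-acylethanolamine-hydrolyzing acid amidase (Rattus norvegicus), read by LC-MS, with a stated time of 30 min; a lower number here means a stronger inhibitor, a higher number a weaker inhibitor:
- compound 1 `Cc1ccccc1-c1ccc(CCC(=O)N2CCCC2)cc1` gives > 100000 nM, which is a limit of the assay rather than a number.
- compound 2 `Cc1cccc(-c2ccc(CCC(=O)N3CCCC3)cc2)c1` gives 16500 nM.
- compound 3 `Cc1ccc(-c2ccc(CCC(=O)N3CCCC3)cc2)cc1` gives 33200 nM.

Compound 3 thus has the higher of the two numbers, while compound 2 sits a 2.0-fold higher number from compound 2 to compound 3 (0.30 log units; within the scatter), within the scatter. Compound 4 `O=C(CCc1ccc(-c2ccccc2F)cc1)N1CCCC1` differs from compound 3 by 2-fluorophenyl in place of 4-methylphenyl on an aromatic carbon. Within the data shown here, the measured step bearing on a 2-substituted phenyl is an at least 3.0-fold lower number from compound 1 to compound 3 (0.47 log units; beyond the scatter), which went from a limit to a number; the reverse direction is what compound 4 approaches, though fluorine replaces methyl and no measured step covers that swap. A modest rise is therefore expected, a 1.8-fold higher number from compound 3 to compound 4 (0.26 log units; within the scatter). Compound 4 is estimated at 60000 nM, in the range 15000 nM to 200000 nM.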

Compound 4, half-maximal inhibitory concentration: 2800 nM
Compound 4: middle estimate off by 21-fold (1.33 log units), on the high side; the measured number lies below the stated range.
By their numbers in this assay, from the lowest: compound 4; then compounds 2 and 3 (each within the scatter of the next). At a limit, above all of these: compound 1.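

Compound 4, with 2-fluorophenyl, stands clearly apart from the methylphenyl compounds in this assay, with a 12-fold lower number from compound 3 to compound 4 (1.07 log units; beyond the scatter) and a 5.9-fold lower number from compound 2 to compound 4 (0.77 log units; beyond the scatter). A group on this 2-position of the phenyl ring is therefore not poor in itself, as compound 1 alone had suggested: fluoro in place of methyl gives an at least 35-fold lower number from compound 1 to compound 4 (1.55 log units; beyond the scatter). That step starts from a limit of the assay for compound 1, not a number: the limit of > 100000 nM in this assay, at which 1 of the 4 values shown sits.

Open, from the compounds shown here alone, is whether 3-fluorophenyl or 4-fluorophenyl would match 2-fluorophenyl. Also open, going by these compounds, is how 2-chlorophenyl or 2-methoxyphenyl would compare.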